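Chloro in Place of Imidazolyl: An Expected Weak Inhibitor

The compounds below may be only part of what the source reports. "The series", "measured", "known", "first", "only" and "open" are said of these compounds alone.

In a functional assay on HT-29 cells (Homo sapiens) for antiproliferative activity, read by MTT assay, with a stated time of 24 h (a lower number here means a stronger inhibitor, a higher number a weaker inhibitor), compound 3 `COc1ccc(C(=O)/C=C/c2ccc(-n3ccnc3)cc2)c2c1C=CC(C)(C)O2` gives > 6600 nM, which is a limit of the assay rather than a number. Compound 2 `CCN(CC)c1ccc(/C=C/C(=O)c2ccc(OC)c3c2OC(C)(C)C=C3)cc1` gives 550 nM in this assay, and the step of an at least 12-fold higher number from compound 2 to compound 3 (1.07 log units; beyond the scatter) is large. Compound 1 `COc1ccc(C(=O)/C=C/c2ccc(F)cc2)c2c1C=CC(C)(C)O2` gives > 10000 nM, again a limit, as the limit of > 10000 nM in this assay, at which 1 of the 3 values shown sits, shows. The step that the two limits leave unreadable from compound 1 to compound 3 therefore cannot be read. Compound 4 `COc1ccc(C(=O)/C=C/c2ccc(Cl)cc2)c2c1C=CC(C)(C)O2` carries chloro in place of 1H-imidazol-1-yl on an aromatic carbon. For the measured compounds named here, the fluoro-bearing compound 1 offers the only comparison for a small halogen at this place, and since it sits at a limit, no measured step bears directly on this change. Compound 4 is therefore expected to remain weak, at roughly 15000 nM in this assay, between 4000 nM and 50000 nM. For compound 4 this estimate means an expected step that the limit leaves unreadable from compound 3 to compound 4.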

Compound 4, half-maximal inhibitory concentration: > 10000 nM
Compound 4 was reported as a limit; the forecaster's own chance of this, stated with the estimate: 75%; the middle value does not contradict the limit.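

Chloro in place of diethylamino on an aromatic carbon, para to a large group, gives an at least 18-fold higher number from compound 2 to compound 4 (1.25 log units; beyond the scatter) in this assay. Compound 2 now stands apart from a second halogen compound as well as from the fluoro compound 1, so the earlier step no longer rests on fluoro alone. The steps joining compound 4 to compound 1 and to compound 3 cannot be read, since each joins two limits: the limit of > 10000 nM in this assay, at which 2 of the 4 values shown sit.

Going by these compounds, whether the chloro, fluoro and 1H-imidazol-1-yl compounds differ from one another stays open. So does whether a dimethylamino group or a carboxylic acid at this place would bring a number like that of compound 2.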